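Oxolan-2-yl for oxan-2-yl in the cytotoxicity series

The source may hold more compounds than are shown below. What is called first, only, known or untested is meant among the compounds shown, and "the series" means these compounds.

Measured so far:
- compound 1 `Oc1ccccc1CNc1ncnc2c1ncn2C1CCCCO1`: > 100000 nM
- compound 2 `COc1ccccc1CNc1ncnc2c1ncn2C1CCCCO1`: > 100000 nM

The measurements come from an ADME assay on BJ cells (Homo sapiens) for cytotoxicity, read by MTT assay, with a stated time of 72 h; a higher number here means a weaker inhibitor, a lower number a stronger inhibitor. In this assay compound 1 gives > 100000 nM, which is a limit of the assay and not a number. Compound 2 gives > 100000 nM, which is also a limit. Compound 1 therefore has no exact value, and its standing is the limit of > 100000 nM in this assay, at which 2 of the 2 values shown sit.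

The next compound is compound 3 `Oc1ccccc1CNc1ncnc2c1ncn2C1CCCO1`. It differs from compound 1 in one place: oxolan-2-yl in place of oxan-2-yl on an aromatic nitrogen. The group sits on an aromatic nitrogen of a five-membered aromatic ring with 2 nitrogen, and both groups carry no net charge.

Going by the values given here, the only measured step is a step that the two limits leave unreadable from compound 1 to compound 2. It lies at a different place in the structure and gives no size to carry over to this change. The expectation therefore rests on (the limit of > 100000 nM in this assay, at which 2 of the 2 values shown sit), and no step beyond the scatter is expected in either direction in this assay. The expected step is a number no higher from compound 1 to compound 3 (the limit leaves the size open). The estimate for compound 3 is 100000 nM, with an expected range of 50000 nM to 200000 nM.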

Compound 3, half-maximal inhibitory concentration: > 100000 nM
Compound 3 ended at the assay's limit; the forecaster's own chance of this, stated with the estimate: 85%; the middle value sits exactly at the limit.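

Compound 3, like compound 1, sits at a limit of this assay and not at a number, so no step can be read for oxolan-2-yl in place of oxan-2-yl. The compounds shown leave open whether any change on the shared core would give an exact value, as all of them stand at one point: the limit of > 100000 nM in this assay, at which 3 of the 3 values shown sit.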